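Removing One Methoxy Group: Expected Effect on Cell Tolerance

This account rests on a few compounds, and the source may have more. Where it says the series, first, only, none or still open, it means among the compounds named here.

Compound 1 `O=C(CN1CCCCC1)Nc1ccc(-c2nc3ccccc3[nH]2)cc1` gives > 100000 nM in an ADME assay on Vero cells (Chlorocebus sabaeus) for cytotoxicity; a higher number here means that more compound is tolerated, a lower number that less compound is tolerated.
Compound 2 `COc1cc(OC)cc(-c2nc3cc(C(F)(F)F)ccc3[nH]2)c1` gives > 100000 nM in this assay.

Both of these readings are limits of the assay rather than measured numbers: neither compound reached a half-maximal cytotoxic concentration within the range tested. Compound 2 therefore stands at the same place as compound 1, both sitting at the limit of > 100000 nM in this assay, at which 2 of the 2 values shown sit, with no number yet separating one from the other.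

Compound 3 `COc1cccc(-c2nc3cc(C(F)(F)F)ccc3[nH]2)c1` has not been tested in this assay. It differs from compound 2 in a single place: hydrogen in place of methoxy on an aromatic carbon. The shared core, including its trifluoromethyl group, and the remaining methoxy group are unchanged.

For the measured compounds named here, because both known values sit at the limit (the limit of > 100000 nM in this assay, at which 2 of the 2 values shown sit), there is no measured step that would point in either direction. The step of a number no higher from compound 2 to compound 3 (the limit leaves the size open) is therefore expected to be none beyond the usual scatter. Compound 3 is expected to give about 100000 nM, within a range of 40000 nM to 200000 nM, and most likely the assay will once more report only a limit rather than a number.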

Compound 3, half-maximal cytotoxic concentration: > 100000 nM
Compound 3 gave a limit, no number; the forecaster's own chance of this, stated with the estimate: 80%; the middle value sits exactly at the limit.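

No step can be read between compound 2 and compound 3, since both readings in this assay are limits of the assay and not numbers: the limit of > 100000 nM in this assay, at which 3 of the 3 values shown sit.

The compounds shown leave open how much compound the cells would actually tolerate in each case, and whether hydrogen in place of methoxy changes that amount at all.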